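The source may hold more compounds than are shown below. What is called first, only, known or untested is meant among the compounds shown, and "the series" means these compounds.

Of the compounds shown here, three sharing one core have been measured in a functional assay on HEK293 cells for agonist activity at G-protein coupled receptor 39 (Homo sapiens), read by scintillation proximity assay and inositol phosphate accumulation, with a stated time of 75 min, in the presence of a further agent that is not named here; a higher number here means that more compound is needed for the effect, a lower number that less compound is needed. Compound 1 `Cc1nn(-c2ncnc3nc[nH]c23)c2c1C(OCC(=O)c1ccc(F)cc1)CC(=O)N2` gives 3 nM in this assay. Compound 2 `Cc1nn(-c2ncnc3nc[nH]c23)c2c1C(OCc1ccc(C(C)C)cc1)CC(=O)N2` gives 5 nM in this assay. Compound 3 `Cc1nn(-c2ncnc3nc[nH]c23)c2c1C(OC(=O)c1ccc(F)cc1)CC(=O)N2` gives 4 nM in this assay, which places it second highest of the three numbers, with compound 2 nearest and compound 1 furthest, every gap lying within the scatter.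

Compound 4 `Cc1nn(-c2ncnc3nc[nH]c23)c2c1C(OCCn1cccn1)CC(=O)N2` is the next step, and it differs from compound 3 by 2-(1H-pyrazol-1-yl)ethyl in place of (4-fluorophenyl)carbonyl on an oxygen on a saturated carbon. Among the measured compounds shown here, the steps that bear on this position are the exchanges on the same oxygen: a 1.3-fold higher number from compound 1 to compound 3 (0.12 log units; within the scatter) and a 1.3-fold lower number from compound 2 to compound 3 (0.10 log units; within the scatter). Both were within the scatter, which shows that three rather different groups on that oxygen gave closely similar numbers. On that basis no step beyond the scatter is expected for a 2.0-fold higher number from compound 3 to compound 4 (0.30 log units; within the scatter), though the new group is smaller and carries no six-membered aromatic ring, so a modest rise in the number is allowed for. Compound 4 is estimated at 8 nM in this assay, with a range from 2 nM to 30 nM.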

Compound 4, half-maximal effective concentration: 16 nM
Estimate against measurement, compound 4: 2.0-fold (0.30 log units) below, within the range that was stated.
By their numbers in this assay, from the lowest: compounds 1, 3 and 2 (each within the scatter of the next); then compound 4.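

The oxygen on a saturated carbon is not indifferent to its substituent after all: in this assay the change to 2-(1H-pyrazol-1-yl)ethyl gives a 4.0-fold higher number from compound 3 to compound 4 (0.60 log units; beyond the scatter) and, measured from the other two compounds, a 3.2-fold higher number from compound 2 to compound 4 (0.51 log units; beyond the scatter) and a 5.3-fold higher number from compound 1 to compound 4 (0.73 log units; beyond the scatter). All three steps are modest but beyond the scatter, whereas the exchanges among the three earlier groups stayed within it, so compound 4, the only one with a five-membered aromatic ring with 2 hetero atoms instead of a six-membered aromatic ring of carbon only, stands apart. Nothing available explains this rise.

The compounds shown do not separate the effect of the pyrazole ring from that of the ethyl chain, which a 2-phenylethyl group on the same oxygen would test. On these data alone, how an amine or a carboxylic acid at the end of that chain would behave also remains open.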